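The compounds below may be only part of what the source reports. "The series", "measured", "known", "first", "only" and "open" are said of these compounds alone.

Three compounds of this set share one core and differ only in the aromatic group at the end of the short chain on the sulfur. Compound 1 `Cn1c(=O)c2c(nc(SCCc3ccc(Br)cc3)n2C)n(C)c1=O` carries a 4-bromophenyl there, and in an assay on microsomes for inhibition of Amine oxidase [flavin-containing] A (Homo sapiens), read by fluorescence and spectrophotometry, with a stated time of 20 min (a lower number here means a stronger inhibitor, a higher number a weaker inhibitor), compound 1 gives 108000 nM. Compound 2 `COc1ccc(CCSc2nc3c(c(=O)n(C)c(=O)n3C)n2C)cc1` carries a 4-methoxyphenyl instead, and in this assay compound 2 gives 168000 nM; the step of a 1.6-fold higher number from compound 1 to compound 2 (0.19 log units; within the scatter) is small. Compound 3 `Cn1c(=O)c2c(nc(SCCc3cccc(Br)c3)n2C)n(C)c1=O` carries a 3-bromophenyl, and in this assay compound 3 gives 5700 nM, the lowest number of the three, with a 19-fold lower number from compound 1 to compound 3 (1.28 log units; beyond the scatter) and a 29-fold lower number from compound 2 to compound 3 (1.47 log units; beyond the scatter) both large and both beyond the scatter.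

Compound 4 `Cn1c(=O)c2c(nc(SCCCc3cccc(Cl)c3)n2C)n(C)c1=O` changes the group once more: 3-chlorobenzyl in place of 3-bromophenyl on a saturated chain carbon, two bonds along the chain from a sulfur. The chain grows by one carbon and chlorine replaces bromine, while the substituent keeps the 3-position of the ring that set compound 3 apart. Within the data shown here, no measured step covers a longer chain or a chlorine for a bromine, so the comparison rests on the shared 3-substitution alone. The expectation is a number near that of compound 3, with the step of a 1.6-fold higher number from compound 3 to compound 4 (0.20 log units; within the scatter) estimated to stay small in this assay. Compound 4 is therefore estimated at 9000 nM in this assay, within a range of 2500 nM to 35000 nM.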

Compound 4, half-maximal inhibitory concentration: 3530 nM
The estimate for compound 4 lay 2.5-fold (0.41 log units) above the measured number; the measured number falls inside the stated range.
By their numbers in this assay, from the lowest: compounds 4 and 3 (each within the scatter of the next); then compounds 1 and 2 (each within the scatter of the next).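

Replacing the 3-bromophenyl of 7 heavy atoms with the 3-chlorobenzyl of 8 heavy atoms, with chlorine in place of bromine, leaves the result in this assay essentially unchanged: a 1.6-fold lower number from compound 3 to compound 4 (0.21 log units; within the scatter). The large gap that first set compound 3 apart now appears for a second compound, with a 31-fold lower number from compound 1 to compound 4 (1.49 log units; beyond the scatter) and a 48-fold lower number from compound 2 to compound 4 (1.68 log units; beyond the scatter), so both compounds bearing a group named with a 3 sit well below the two bearing a group named with a 4, and none of the four goes against this. No measurement shown explains why these groups differ in this way.

Compound 4 changes the group in two ways at once, so the effect of the chlorine cannot be separated from that of the larger group, and a 3-chlorophenyl and a 3-bromobenzyl would be the compounds that could separate them. Going by these compounds, it also remains open whether a 3-methoxyphenyl, a 4-chlorobenzyl or a longer chain ending in a 3-chlorophenyl would follow the same pattern.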